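The source may hold more compounds than are shown below. What is called first, only, known or untested is meant among the compounds shown, and "the series" means these compounds.

Measured in a functional assay on PC-3 cells (Homo sapiens) for antiproliferative activity, with a stated time of 48 h; on this read-out higher numbers stand for weaker inhibition and lower numbers for stronger inhibition:
- Compound 1 `CCN(CC)c1ccc(-c2cccc(C(F)(F)F)c2)nn1`: > 25000 nM, a limit
- Compound 2 `CCN(CC)c1ccc(-c2cccc(C#N)c2)nn1`: > 25000 nM, a limit

Among the measured compounds shown here, compound 1 has no number on this read-out, only a limit, and the same is true of the one other compound measured. Together they make up (the limit of > 25000 nM in this assay, at which 2 of the 2 values shown sit). For the measured compounds named here, the only measured step is a step that the two limits leave unreadable from compound 1 to compound 2, with cyano in place of trifluoromethyl on an aromatic carbon, so it offers no size to carry forward.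

Compound 3 `CN1CCN(c2ccc(-c3cccc(C(F)(F)F)c3)nn2)CC1` keeps the trifluoromethyl of compound 1 and changes the amine instead: 4-methylpiperazin-1-yl in place of diethylamino on an aromatic carbon. This places 4-methylpiperazin-1-yl in place of diethylamino on an aromatic carbon. Going by the values given here, no measured step covers this change, so neither its size nor its direction can be read from the data. With only the limit of > 25000 nM in this assay, at which 2 of the 2 values shown sit, to go on, no step beyond the scatter is expected in this assay, and a further limit is the likeliest result. The expected step is a step that the limit leaves unreadable from compound 1 to compound 3. For compound 3 the estimated value is 30000 nM, with an expected range from 10000 nM to 80000 nM.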

Compound 3, half-maximal inhibitory concentration: > 25000 nM
Compound 3 gave a limit, no number; the forecaster's own chance of this, stated with the estimate: 65%; the middle value is on the limit's open side.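

Compound 3, like compound 1, gave only a limit, so no step can be read between them, and the change from diethylamino to 4-methylpiperazin-1-yl has no readable size. The compounds shown leave open whether changing the amine or the aromatic substituent alters activity at all, with every value at one limit: the limit of > 25000 nM in this assay, at which 3 of the 3 values shown sit.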